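The source may hold more compounds than are shown below. What is called first, only, known or untested is meant among the compounds shown, and "the series" means these compounds.

Compound 1 `C=C1[C@@H](OC(C)=O)C[C@@H]2[C@](C)(CO[Si](C)(C)C(C)(C)C)[C@H](OC(C)=O)CC[C@@]2(C)[C@@H]1C[C@@H](Nc1ccc(Br)cc1)C1=CCOC1=O` is the most potent of the three measured compounds in a functional assay on HT-29 cells (Homo sapiens) for cytotoxicity, read by sulforhodamine B assay (on this read-out higher numbers stand for weaker inhibition and lower numbers for stronger inhibition), where compound 1 gives 4590 nM. Within the data shown here, compound 3 `C=C1[C@@H](OC(C)=O)C[C@@H]2[C@](C)(COC=O)[C@H](OC(C)=O)CC[C@@]2(C)[C@@H]1C[C@@H](Nc1ccc(Br)cc1)C1=CCOC1=O` gives 13200 nM in this assay, and the only change between them, a smaller group on the oxygen of the saturated carbon, gives a 2.9-fold higher number from compound 1 to compound 3 (0.46 log units; beyond the scatter). Compound 2 `C=C1[C@@H](OC(C)=O)C[C@@H]2[C@](C)(COC=O)[C@H](OC(C)=O)CC[C@@]2(C)[C@@H]1C[C@@H](Nc1ccccc1C(=O)O)C1=CCOC1=O` gives 28700 nM in this assay; swapping its aryl group on the amine nitrogen gives a 2.2-fold lower number from compound 2 to compound 3 (0.34 log units; beyond the scatter).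

Compound 4 `C=C1[C@@H](OC(C)=O)C[C@@H]2[C@](C)(CO[Si](C)(C)C(C)(C)C)[C@H](OC(C)=O)CC[C@@]2(C)[C@@H]1C[C@@H](Nc1cccc(OC)c1)C1=CCOC1=O` differs from compound 1 only on that same amine nitrogen: 3-methoxyphenyl in place of 4-bromophenyl on an amine nitrogen. Among the measured compounds shown here, no measured step exchanges a bromophenyl for a methoxyphenyl, so the only guide is the aryl swap on the amine in the step from compound 2 to compound 3, which was modest. A modest step in this assay is therefore expected here as well, with direction uncertain and a slight lean toward a higher number because compound 1 already gives 4590 nM, the lowest number measured. Compound 4 is estimated at 7000 nM, within 3000 nM to 17000 nM. This expectation corresponds to a 1.5-fold higher number from compound 1 to compound 4 (0.18 log units; within the scatter).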

Compound 4, half-maximal inhibitory concentration: > 50000 nM
Compound 4 ended at the assay's limit; the forecaster's own chance of this, stated with the estimate: 5%; middle value at least 7.1-fold (0.85 log units) away from the limit.
By their numbers in this assay, from the lowest: compound 1; then compound 3; then compound 2. At a limit, above all of these: compound 4.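

Among these compounds, on the amine nitrogen, replacing 4-bromophenyl with 3-methoxyphenyl gives an at least 10-fold higher number from compound 1 to compound 4 (1.03 log units; beyond the scatter), a large step, whereas the only earlier aryl swap at this place gave just a 2.2-fold lower number from compound 2 to compound 3 (0.34 log units; beyond the scatter). The aryl group here can therefore matter far more than compounds 1, 2 and 3 suggested, and in this series a change of similar size, with the same single aromatic ring, can take a compound out of the range that can be read. Compound 4 gives no exact number in this assay, only a limit, so its step is a lower bound: the limit of > 50000 nM in this assay, at which 1 of the 4 values shown sits.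

The compounds shown leave open whether the methoxy group itself or its place on the ring goes with this change, since both differ at once. A 4-methoxyphenyl or a 3-bromophenyl group on the same amine nitrogen would separate the two.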